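A few compounds are considered here, and "the series" means these few. Any claim that something is new, unique, unknown or untested is made for them only; others in the source may bear on it.

In a functional assay on NCI-H2228 cells (Homo sapiens) for inhibition, read by CellTiter-Glo, with a stated time of 96 h (on this read-out lower numbers stand for stronger inhibition and higher numbers for weaker inhibition), the measured compounds are:
Compound 1 `CC(C)S(=O)(=O)c1nn(C)cc1Nc1nc(Nc2cc(C#N)c(C3CCN(C)CC3)cc2OC2CC2)ncc1Cl` gives 165 nM
Compound 2 `Cc1cc(Nc2ncc(Cl)c(Nc3cn(C)nc3S(=O)(=O)C(C)C)n2)c(OC2CC2)cc1C(=O)C(C)C` gives 149 nM
Compound 3 `Cc1cc(Nc2ncc(Cl)c(Nc3cn(C)nc3S(=O)(=O)C(C)C)n2)c(OC2CC2)cc1C1CCCN(C)C1` gives 32 nM

Compound 3 holds the lowest of the three numbers, and both other compounds lie beyond the scatter from it. Compound 4 `CCNC(=O)c1cc(OC2CC2)c(Nc2ncc(Cl)c(Nc3cn(C)nc3S(=O)(=O)C(C)C)n2)cc1C` keeps the shared core but carries ethylcarbamoyl in place of 1-methylpiperidin-3-yl on an aromatic carbon. Among the measured compounds shown here, one measured step bears on this change: a 4.7-fold lower number from compound 2 to compound 3 (0.67 log units; beyond the scatter) when 1-methylpiperidin-3-yl took the place of isopropylcarbonyl on that same carbon. Compound 4 loses the same ring and, like compound 2, has a carbonyl-bearing group there. A modest step of similar size in the opposite direction, to a higher number, is therefore expected. For the measured compounds named here, the two groups differ, however, and no measured compound carries ethylcarbamoyl, so the range stays wide. The expected step in this assay is a 4.4-fold higher number from compound 3 to compound 4 (0.64 log units; beyond the scatter) by estimate. Compound 4 is estimated at 140 nM (expected range 55 nM to 350 nM).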

Compound 4, half-maximal inhibitory concentration: 82 nM
Compound 4: middle estimate off by 1.7-fold (0.23 log units), on the high side, and the stated range covers the measured number.
By their numbers in this assay, from the lowest: compound 3; then compounds 4, 2 and 1 (each within the scatter of the next).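

On this aromatic carbon in this assay the open-chain ethylcarbamoyl group does not match the 1-methylpiperidin-3-yl group (a 2.6-fold higher number from compound 3 to compound 4 (0.41 log units; beyond the scatter)), so the gap that compound 3 showed against a single carbonyl-bearing group now holds against a second one. Exchanging isopropyl for ethylamino on the carbonyl carbon gives a step within the scatter (a 1.8-fold lower number from compound 2 to compound 4 (0.26 log units; within the scatter)), so the amide hydrogen that enters with ethylamino leaves no reading in this assay beyond that scatter, and compounds 2 and 4 cannot be told apart here. No measurement at hand accounts for either step.

The compounds shown leave open whether the ring carbons or the ring nitrogen carry the gap, which a cyclohexyl group or an open-chain amine such as dimethylaminomethyl on the same carbon would separate. They also leave open whether the piperidine needs its methyl group, since the same ring with a hydrogen on its nitrogen does not appear among them.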